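Replacing an Aryl Ether with a Dimethylmorpholine

The source may hold more compounds than are shown below. What is called first, only, known or untested is meant among the compounds shown, and "the series" means these compounds.

In an ADME assay on a cell-free system (plasma, Homo sapiens) for protein binding, using equilibrium dialysis, with a stated time of 4 h (on this read-out lower numbers stand for a smaller free fraction and higher numbers for a larger free fraction), compound 1 (`NC(=O)c1cc(-c2ccc(F)cc2)n2nc(CCc3ccnc(C(F)(F)F)c3)cc2n1`) gives 0.02 and compound 3 (`COc1ccc(-c2cc(C(N)=O)nc3cc(COc4cnc(C)nc4)sc23)cc1`) gives 0.01 as its reading. Compound 2 (`Cc1ccc(OCc2cc3nc(C(N)=O)cc(-c4ccc(F)cc4)c3s2)cn1`) stands highest of the three at 0.05 and lies beyond the scatter from both of the others. Compound 4 (`C[C@@H]1CN(Cc2cc3nc(C(N)=O)cc(-c4ccc(F)cc4)c3s2)C[C@H](C)O1`) takes compound 2 and puts 2,6-dimethylmorpholin-4-yl in place of (6-methylpyridin-3-yl)oxy on a saturated chain carbon bound to an aromatic carbon. Going by the values given here, no measured pair isolates a change of this kind, so the expectation remains tentative. A small rise is expected in this assay for this step (a 1.6-fold higher number from compound 2 to compound 4 (0.20 log units; within the scatter)) and it may well stay within the scatter. Compound 4 is estimated at 0.08 on this read-out, with an expected range (0.03 to 0.2).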

Compound 4, unbound fraction: 0.01
For compound 4 the middle estimate is 8.0-fold (0.90 log units) above the measured one; measured number outside the range, below it.
By their numbers in this assay, from the lowest: compounds 3, 4 and 1 (each within the scatter of the next); then compound 2.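

In this assay, the one-place step from (6-methylpyridin-3-yl)oxy to 2,6-dimethylmorpholin-4-yl on the saturated chain carbon gives a 5.0-fold lower number from compound 2 to compound 4 (0.70 log units; beyond the scatter), which lies beyond the scatter. The two groups have equal counts of heavy atoms, donors and acceptors, yet the free fraction still falls when the aromatic ring gives way to the non-aromatic one. Nothing measured here explains this fall. On these data alone, how an unsubstituted morpholine or a piperidine on the same carbon would read remains open. So does whether the two defined stereocentres of compound 4 bear on its reading.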